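This account rests on a few compounds, and the source may have more. Where it says the series, first, only, none or still open, it means among the compounds named here.

Of the compounds shown here, three have been tested so far in a functional assay on CHO-K1 cells for agonist activity at Glucose-dependent insulinotropic receptor (Mus musculus), read by HTRF and cAMP accumulation, with a stated time of 30 min (on this read-out lower numbers stand for smaller maximal responses and higher numbers for larger maximal responses), and they share a piperidine-linked aminoalkyl chain attached to a bicyclic ketone, while the group on the ring nitrogen and the exact core vary. Compound 1 `CCc1cnc(N2CCC(CCCNc3ccc4c(c3)C(=O)CC4)CC2)nc1` reaches 110% in this assay. Compound 2 `CC(C)(C)OC(=O)N1CCC(CCCNc2ccc3c(c2)C(=O)CCO3)CC1` reaches 108%. Compound 3 `COC(=O)c1cnc(N2CCC(CCCNc3ccc4c(c3)OCC4=O)CC2)nc1` reaches only 67%, which is the lowest of the three numbers: its nearest neighbour is compound 2, whose number lies beyond the scatter above it, and compound 1 lies slightly further still, also beyond the scatter.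

Compound 4 `CC(C)c1nnc(N2CCC(CCCNc3ccc4c(c3)OCC4=O)CC2)o1` has not yet been measured. It keeps the core of compound 3 and differs from it in a single place: 5-isopropyl-1,3,4-oxadiazol-2-yl in place of 5-(methoxycarbonyl)pyrimidin-2-yl on an amine nitrogen in a ring. Going by the values given here, no step between two measured compounds with this same change is available, so any expectation has to rest on compound 3 alone and on the fact that the other two compounds, with different groups on the same ring nitrogen, reach clearly larger responses. On that basis a moderate rise from compound 3 to compound 4 is expected, a number 18 percentage points higher from compound 3 to compound 4 (beyond the scatter), though a number within the scatter of compound 3 would not be surprising. Compound 4 is therefore estimated to reach 85%, with a likely range from 55% to 110%.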

Compound 4, largest response reached (Emax), in percent of the reference or control that the assay uses: 88%
Compound 4: middle estimate off by 3 percentage points, on the low side, within the range that was stated.
By their numbers in this assay, from the lowest: compound 3; then compound 4; then compounds 2 and 1 (each within the scatter of the next).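

With the core held fixed, placing 5-isopropyl-1,3,4-oxadiazol-2-yl in place of 5-(methoxycarbonyl)pyrimidin-2-yl on the amine nitrogen of the six-membered non-aromatic ring gives a number 21 percentage points higher from compound 3 to compound 4 (beyond the scatter) in this assay. Going by these compounds alone, this is the first pair that differs in one place only, and it shows directly that the group on this nitrogen can change the maximal response without any change to the rest of the molecule. The change replaces a six-membered aromatic ring with a five-membered one and also swaps the group carried on that ring, and no available evidence explains the step.

Within the data shown here, the single step cannot say whether the new ring or the isopropyl group accounts for the rise, and a 5-methyl-1,3,4-oxadiazol-2-yl or a 5-isopropylpyrimidin-2-yl group at this position would be needed to separate the two. On these data alone, it also remains open how a free carboxylic acid in place of the methyl ester on the pyrimidine ring would behave, and compounds 1 and 2 differ from compound 4 in more than one place, so they cannot answer these questions.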